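The source may report more compounds than this note shows. Statements on the series, on what has been measured and on what is new or still open speak of the compounds shown alone.

Compound 1 `CSc1ccc(C2=C(c3ccc(F)c(F)c3)C(=O)N3CCCC3C2)cc1`: 200 nM
Compound 2 `CSc1ccc(C2=C(c3ccc(Br)cc3)C(=O)N3CCCC3C2)cc1`: 7000 nM

Going by the values given here, in a functional assay on NCI-H520 cells (Homo sapiens) for cytotoxicity (on this read-out lower numbers stand for stronger inhibition of growth and higher numbers for weaker inhibition of growth), compound 2 stands at 7000 nM, the higher of the two numbers known so far, which makes it the weaker growth inhibitor of the pair. Compound 3 `CSc1ccc(C2=C(c3ccc(C)cc3)C(=O)N3CCCC3C2)cc1` keeps all of compound 2 except one group: methyl in place of bromo on an aromatic carbon. In words, this is methyl in place of bromo on an aromatic carbon, so 4-bromophenyl becomes 4-methylphenyl.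

Among the compounds with values here, only one measured step bears on this change: a 35-fold higher number from compound 1 to compound 2 (1.54 log units; beyond the scatter). It was large and altered the same aryl group, so the read-out clearly responds to changes there. Within the data shown here, still, no measured compound carries a methyl, and a single step cannot fix a direction for this swap. The direction expected here is a cautious one, resting on compound 2 having the higher number and compound 1 reaching 200 nM with a different aryl group. A modest move is expected, estimated as a 2.3-fold lower number from compound 2 to compound 3 (0.37 log units; beyond the scatter). For compound 3 the expected value is 3000 nM, with an estimated range from 600 nM to 10000 nM.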

Compound 3, concentration for 50% growth inhibition: 900 nM
Compound 3: the middle estimate sits 3.3-fold (0.52 log units) above what was measured; the measured number falls inside the stated range.
By their numbers in this assay, from the lowest: compound 1; then compound 3; then compound 2.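

Within this assay, the swap from 4-bromophenyl to 4-methylphenyl gives a 7.8-fold lower number from compound 2 to compound 3 (0.89 log units; beyond the scatter) even though one heavy atom simply replaces another and the rest of the molecule stays the same. Going by these compounds alone, the earlier step between compound 1 and compound 2 changed both the identity and the number of groups on this phenyl ring, whereas this pair shows that the single group at the 4-position can shift the number well beyond the scatter on its own. Changing the aryl group in the other pair gives a 4.5-fold higher number from compound 1 to compound 3 (0.65 log units; beyond the scatter), so the 3,4-difluorophenyl of compound 1 still has the lowest number of the three, with 4-methylphenyl in the middle and 4-bromophenyl highest, and no measurement shown here accounts for these differences.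

On these data alone, it remains open whether a single fluoro, a methoxy, an amine or a carboxylic acid on this ring would land nearer to compound 1 or to compound 2. It is equally unclear whether a longer chain such as ethyl would keep the lower number seen with methyl, or whether methyl is already the limit of what this position tolerates.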